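Chloro to methoxy on the shared core

The source may hold more compounds than are shown below. What is called first, only, known or untested is meant among the compounds shown, and "the series" means these compounds.

Measured in a functional assay on CCRF-CEM cells (Homo sapiens); on this read-out higher numbers stand for weaker inhibition and lower numbers for stronger inhibition:
compound 1 `Cc1ccc(-c2ncnc3c2ncn3C[C@@H]2C[C@H](CO)c3ccccc32)cc1`: 1.4 ug/mL
compound 2 `CCOc1ncnc2c1ncn2C[C@@H]1C[C@H](CO)c2ccccc21`: 24 ug/mL
compound 3 `OC[C@H]1C[C@@H](Cn2cnc3c(Cl)ncnc32)c2ccccc21`: 24 ug/mL

Compound 3 stands level with compound 2, and together they hold the highest number of the three, which here means the weakest inhibition. Only compound 1 lies clearly lower.

The next compound, compound 4 `COc1ncnc2c1ncn2C[C@@H]1C[C@H](CO)c2ccccc21`, keeps the shared core and changes one group, methoxy in place of chloro on an aromatic carbon.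

The most relevant evidence is no change at the digits printed from compound 2 to compound 3 (within the scatter), where chloro took the place of ethoxy, the group most like methoxy among those measured. That step stays within the scatter. The two large steps, a 17-fold higher number from compound 1 to compound 2 (1.23 log units; beyond the scatter) and a 17-fold higher number from compound 1 to compound 3 (1.23 log units; beyond the scatter), both involve losing 4-methylphenyl, which plays no part in this change. They show that this position can matter, but they say little about swapping one small group for another.

No step beyond the scatter is therefore expected in this assay. The expected outcome is no change at the digits printed from compound 3 to compound 4 (within the scatter). For compound 4 the estimated value is 24 ug/mL, within an expected range of 10 ug/mL to 55 ug/mL.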

Compound 4, half-maximal inhibitory concentration: 24 ug/mL
Compound 4: middle estimate and measured number agree at the digits printed; the measured number falls inside the stated range.
By their numbers in this assay, from the lowest: compound 1; then compounds 2, 3 and 4 (each within the scatter of the next).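

With methoxy in the series, three small groups on this aromatic carbon can now be compared directly in this assay (chloro to methoxy gives no change at the digits printed from compound 3 to compound 4 (within the scatter) and shortening ethoxy to methoxy gives no change at the digits printed from compound 2 to compound 4 (within the scatter)), so neither swapping chloro for an oxygen-linked group nor removing one carbon from the ethoxy chain separates these compounds. Methoxy also falls on the same side of the large gap as chloro and ethoxy, with a 17-fold higher number from compound 1 to compound 4 (1.23 log units; beyond the scatter) and 4-methylphenyl the only group here that stands apart. No measurement is available that explains why the three small groups read alike.

As far as these compounds go, it remains open whether an amine or a longer chain such as butoxy at this carbon would match the small groups or approach 4-methylphenyl. Plain phenyl would show whether the ring alone accounts for the gap or its methyl also contributes.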